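Alkylating the Aromatic Nitrogen of the Shared Core

This account rests on a few compounds, and the source may have more. Where it says the series, first, only, none or still open, it means among the compounds named here.

Compound 2 `O=C1c2c[n+]([O-])c3ccccc3c2C(=O)c2[nH]c3ccccc3c21` carries a hydrogen on the aromatic nitrogen of its core. Within the data shown here, in a functional assay on A549 cells (Homo sapiens) for cytotoxicity, read by MTT assay, with a stated time of 72 h (on this read-out higher numbers stand for weaker inhibition and lower numbers for stronger inhibition), compound 2 gives 320 nM, the second highest of the three numbers known. Compound 1 `CC1(C)O[C@@H](CO)[C@H](Cn2cc(Cn3c4c(c5ccccc53)C(=O)c3c[n+]([O-])c5ccccc5c3C4=O)nn2)O1` gives 370 nM in this assay, which lies within the scatter of compound 2, while compound 3 `O=C1c2c[n+]([O-])c3ccccc3c2C(=O)c2c1c1ccccc1n2Cc1cn([C@@H]2C[C@H](O)[C@@H](CO)O2)nn1` gives 120 nM. Among the measured compounds shown here, the one step seen, a 3.1-fold lower number from compound 1 to compound 3 (0.49 log units; beyond the scatter), compares two substituents on that nitrogen and says nothing directly about replacing the hydrogen. Compound 4 `CN(C)CCCCn1c2c(c3ccccc31)C(=O)c1c[n+]([O-])c3ccccc3c1C2=O` differs from compound 2 by 4-(dimethylamino)butyl in place of hydrogen on an aromatic nitrogen. The two substituted compounds stand near or beneath compound 2, so a modest downward step is expected, a 1.6-fold lower number from compound 2 to compound 4 (0.20 log units; within the scatter). Compound 4 is estimated at 200 nM, with a range from 70 nM to 600 nM.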

Compound 4, half-maximal inhibitory concentration: 310 nM
Compound 4: the middle estimate sits 1.6-fold (0.19 log units) below what was measured; the measured number falls inside the stated range.
By their numbers in this assay, from the lowest: compound 3; then compounds 4, 2 and 1 (each within the scatter of the next).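

In this assay, among these compounds, the step of a 1.0-fold lower number from compound 2 to compound 4 (0.01 log units; within the scatter) gives the first direct reading of replacing hydrogen on this aromatic nitrogen: with 4-(dimethylamino)butyl there, the two numbers lie within the scatter of each other. So this position accepts this chain, which has no ring, without a difference that can be told from the scatter. No measurement at hand speaks to what lies behind this result. Still open, going by these compounds, is how a shorter or longer chain would read at this nitrogen, or a carboxylic acid or primary amine at the chain's end.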